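Compound 4: hydrogen in place of 4-ethylcyclohexyl

The source may report more compounds than this note shows. Statements on the series, on what has been measured and on what is new or still open speak of the compounds shown alone.

Going by the values given here, in an ADME assay on MT4 cells (Homo sapiens) for cytotoxicity (a higher number here means that more compound is tolerated, a lower number that less compound is tolerated), compound 1 (`CC[C@H]1CC[C@H](c2ccc(NC(=S)Nc3cccc(C(F)(F)F)c3)cc2)CC1`) gives 39000 nM as the highest of the three numbers measured so far. Compound 2 (`FC(F)(F)c1cccc(NC(=S)Nc2ccc(Cl)cc2)c1`) gives 6800 nM and compound 3 (`Fc1ccc(NC(=S)Nc2cccc(C(F)(F)F)c2)cc1Cl`) gives 8000 nM as two values lying close together. Compound 4 (`FC(F)(F)c1cccc(NC(=S)Nc2ccccc2)c1`) has not yet been measured. It comes from compound 1 by hydrogen in place of 4-ethylcyclohexyl on an aromatic carbon. Among the compounds with values here, the one measured step that bears on this is a 5.7-fold lower number from compound 1 to compound 2 (0.76 log units; beyond the scatter) with chloro in place of 4-ethylcyclohexyl at that same carbon. Compound 3 also lacks 4-ethylcyclohexyl and also stands well under compound 1. Within the data shown here, no measured compound carries hydrogen at that place, so the size of the step stays uncertain. A lower number in this assay is expected, of similar or somewhat smaller size than the chloro step. The expected move is a 3.3-fold lower number from compound 1 to compound 4 (0.51 log units; beyond the scatter) as an estimate only. Compound 4 is therefore estimated at 12000 nM within an expected range of 5000 nM to 30000 nM for now.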

Compound 4, half-maximal cytotoxic concentration: 39000 nM
Beside the measured number, compound 4's estimate is 3.3-fold (0.51 log units) below it; the whole stated range lies below it.
By their numbers in this assay, from the lowest: compounds 2 and 3 (each within the scatter of the next); then compounds 1 and 4 (each within the scatter of the next).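

In this assay, hydrogen in place of 4-ethylcyclohexyl on this aromatic carbon brings no change at the digits printed from compound 1 to compound 4 (within the scatter), so losing that large group does not by itself move the number. Hydrogen in place of chloro at the same carbon brings a 5.7-fold higher number from compound 2 to compound 4 (0.76 log units; beyond the scatter), which ties the lower number of compound 2 to the chloro group rather than to the absence of 4-ethylcyclohexyl. Nothing available here explains why chloro and hydrogen differ at this carbon.

As far as these compounds go, it remains open whether other small groups at this carbon, such as methoxy, an amine or a carboxylic acid, would track chloro or hydrogen. From the compounds shown here alone, it is also open whether a simple ethyl chain would match hydrogen and 4-ethylcyclohexyl in this assay's read-out.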